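Acyl variation on a tricyclic amide series

The compounds below may be only part of what the source reports. "The series", "measured", "known", "first", "only" and "open" are said of these compounds alone.

Measured so far:
compound 1 `CC(=O)N1CCc2c(C)c3c(n2-c2ccc(C(N)=O)c(c2)N[C@@H](C)[C@H](C)C1)CC(C)(C)CC3=O` — 24 nM
compound 2 `Cc1c2c(n3c1CCCN(C(=O)CN)[C@@H](C)[C@H](C)Nc1cc-3ccc1C(N)=O)CC(C)(C)CC2=O` — 147 nM

In a functional assay on HCT-116 cells (Homo sapiens) for antiproliferative activity (on this read-out lower numbers stand for stronger inhibition and higher numbers for weaker inhibition), compound 1 gives 24 nM, the lower of the two numbers recorded. Among the measured compounds shown here, compound 2 gives 147 nM, a gap beyond the usual scatter; the two compounds differ in more than one place, so the two values show only that compound 2 is the weaker of the pair, not which change carries the loss.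

Compound 3 `Cc1c2c(n3c1CCN(C(=O)C1(N)CC1)C[C@@H](C)[C@H](C)Nc1cc-3ccc1C(N)=O)CC(C)(C)CC2=O` is the next point. Relative to compound 1 the change is 1-aminocyclopropyl in place of methyl on a carbonyl carbon. For the measured compounds named here, no single-point step of this kind has been measured here. The acyl group that enters carries an additional hydrogen-bond donor and acceptor, and compound 2, which also carries an amine on its acyl group, sits at 147 nM. A modest loss is therefore expected, the step from compound 1 a 2.3-fold higher number from compound 1 to compound 3 (0.36 log units; beyond the scatter), within or just beyond the scatter. Compound 3 is estimated at 55 nM, with a range from 18 nM to 180 nM.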

Compound 3, half-maximal inhibitory concentration: 81 nM
Compound 3: the middle estimate sits 1.5-fold (0.17 log units) below what was measured, and the stated range covers the measured number.
By their numbers in this assay, from the lowest: compound 1; then compounds 3 and 2 (each within the scatter of the next).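

In this assay, among the compounds shown here, this is the first single-place step: 1-aminocyclopropyl in place of methyl on the carbonyl carbon gives a 3.4-fold higher number from compound 1 to compound 3 (0.53 log units; beyond the scatter), a modest loss. The position therefore accepts a larger acyl group carrying an amine and a three-membered ring, with compound 3 still at 81 nM in this read-out. No measurement shown here accounts for the size of the step.

This step alone does not separate the contribution of the amine from that of the three-membered ring, and cyclopropyl without the amine on the same carbonyl carbon would address that split. Going by these compounds, how a hydroxyl group or a carboxylic acid in place of the amine would read at this position also remains open.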